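The source may report more compounds than this note shows. Statements on the series, on what has been measured and on what is new or still open speak of the compounds shown alone.

In an ADME assay on MT4 cells (Homo sapiens) for cytotoxicity, read by MTT assay, with a stated time of 5 days (on this read-out higher numbers stand for lower toxicity in this test and lower numbers for higher toxicity in this test), three compounds have been measured so far.

Compound 1 `Cc1ccc(Cn2cc(CNC(=O)c3cnc(Nc4ccc(C#N)cc4)cc3Oc3c(C)cc(C)cc3C)nn2)cc1` gives 165000 nM.
Compound 2 `Cc1cc(C)c(Oc2cc(Nc3ccc(C#N)cc3)ncc2C(=O)NCc2cn(Cc3ccccc3F)nn2)c(C)c1` gives > 222000 nM.
Compound 3 `Cc1cc(C)c(Oc2cc(Nc3ccc(C#N)cc3)ncc2C(=O)NCc2cn(Cc3cccc(Cl)c3)nn2)c(C)c1` gives 187000 nM.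

All three share one core and differ only in the group on a saturated chain carbon bound to an aromatic nitrogen. For compound 2 the assay reports only a limit, not a number, the limit being (the limit of > 222000 nM in this assay, at which 1 of the 3 values shown sits), so its exact place among the three is not fixed. Compound 4 `Cc1cc(C)c(Oc2cc(Nc3ccc(C#N)cc3)ncc2C(=O)NCc2cn(Cc3ccc(Cl)cc3)nn2)c(C)c1` is the compound still to be measured. It differs from compound 2 in one place: 4-chlorophenyl in place of 2-fluorophenyl on a saturated chain carbon bound to an aromatic nitrogen.

Among the compounds with values here, three measured steps bear on this change, all of them exchanges of one substituted phenyl for another at the same place: an at least 1.3-fold higher number from compound 1 to compound 2 (0.12 log units; that floor lies within the scatter), a 1.1-fold higher number from compound 1 to compound 3 (0.05 log units; within the scatter) and an at least 1.1-fold lower number from compound 2 to compound 3 (0.07 log units; that floor lies within the scatter). None of these exchanges moved the reading beyond the scatter. A further exchange of the same kind is therefore expected to give no step beyond the scatter, in no fixed direction, which is what the estimated step of an at least 1.1-fold lower number from compound 2 to compound 4 (0.05 log units; that floor lies within the scatter) means. In this assay compound 4 is estimated at 195000 nM, with an expected range from 120000 nM to 300000 nM.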

Compound 4, half-maximal cytotoxic concentration: >= 120000 nM
Compound 4 ended at the assay's limit; the forecaster's own chance of this, stated with the estimate: 40%; the middle value does not contradict the limit.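

In this assay, no step from compound 1, compound 2 or compound 3 to compound 4 can be read, because compound 4 carries only a limit: the limit of >= 120000 nM in this assay, at which 1 of the 4 values shown sits.

The compounds shown leave open where compound 4 stands relative to compound 1 and compound 3, and whether 4-chlorophenyl in place of 2-fluorophenyl changes the reading from compound 2 at all.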